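Working notes: replacing the methylsulfonylphenyl group of compound 2

The compounds below may be only part of what the source reports. "The series", "measured", "known", "first", "only" and "open" are said of these compounds alone.

compound 1 `Cc1ccc(-c2nc3c(c(C)nn3-c3ccccc3)c(-c3ccccc3O)c2C#N)cc1`: 26000 nM
compound 2 `Cc1nn(-c2ccccc2)c2nc(-c3ccc(S(C)(=O)=O)cc3)c(C#N)c(-c3ccccc3O)c12`: 5000 nM

In a physicochemical assay for solubility, read by spectrophotometry, in phosphate buffer, with a stated time of 18 h, at pH 7.4 (a lower number here means a less soluble compound, a higher number a more soluble compound), compound 2 holds the lower of the two values, 5000 nM. Compound 3 `Cc1nn(-c2ccccc2)c2nc(-c3ccc4c(c3)CCCC4)c(C#N)c(-c3ccccc3O)c12` differs from it by 1,2,3,4-tetrahydronaphthalen-6-yl in place of 4-(methylsulfonyl)phenyl on an aromatic carbon, with 1,2,3,4-tetrahydronaphthalen-6-yl in place of 4-(methylsulfonyl)phenyl on an aromatic carbon. Going by the values given here, one measured step bears on this: the modest, beyond-scatter a 5.2-fold lower number from compound 1 to compound 2 (0.72 log units; beyond the scatter), which introduced the methylsulfonyl group that now leaves. A modest rise of similar or somewhat smaller size is therefore expected, and the estimated step is a 2.4-fold higher number from compound 2 to compound 3 (0.38 log units; beyond the scatter). Compound 3 is expected at 12000 nM, with an estimated range of 3000 nM to 40000 nM.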

Compound 3, solubility: 13000 nM
Estimate against measurement, compound 3: 1.1-fold (0.03 log units) below; the range from low to high includes it.
By their numbers in this assay, from the lowest: compound 2; then compounds 3 and 1 (each within the scatter of the next).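

Working from this assay, the 1,2,3,4-tetrahydronaphthalen-6-yl group gives a 2.6-fold higher number from compound 2 to compound 3 (0.41 log units; beyond the scatter) and so shows that a second group carrying no methylsulfonyl also stands clear of compound 2 at this position. The other new step (a 2.0-fold lower number from compound 1 to compound 3 (0.30 log units; within the scatter)) lies within the scatter, so 1,2,3,4-tetrahydronaphthalen-6-yl and 4-methylphenyl cannot be told apart here. No supporting data accompany these readings to explain them.

Open, on these data alone, is how an amine or a carboxylic acid on this aromatic carbon would read. Also open, as far as these compounds go, is whether the methylsulfonyl step carries over to other cores.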